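Glycolamide in place of chlorobenzyl ester on a cinnamate

The source may hold more compounds than are shown below. What is called first, only, known or untested is meant among the compounds shown, and "the series" means these compounds.

Measured so far in an ADME assay (liver) for pharmacokinetics, with Liver microsome (Rattus norvegicus) as the target, using microsomes; a higher number here means that the compound lasts longer, a lower number that the compound disappears faster:
compound 1, `CCOc1cc(NC(=O)C2(NC(=O)c3ccc4c(C5CCCC5)c(-c5ncc(Cl)cn5)n(C)c4c3)CCC2)ccc1/C=C/C(=O)OCOP(=O)(O)O`, gives 0.15 h;
compound 2, `CCOc1cc(NC(=O)C2(NC(=O)c3ccc4c(C5CCCC5)c(-c5ncc(Cl)cn5)n(C)c4c3)CCC2)ccc1/C=C/C(=O)OCC(=O)OCc1ccc(Cl)cc1`, gives 11.4 h.

Within the data shown here, compound 2 holds the highest of the two numbers in this assay; its only neighbour is compound 1, and the two are separated by a large step, a 76-fold higher number from compound 1 to compound 2 (1.88 log units; beyond the scatter). Compound 3, `CCOc1cc(NC(=O)C2(NC(=O)c3ccc4c(C5CCCC5)c(-c5ncc(Cl)cn5)n(C)c4c3)CCC2)ccc1/C=C/C(=O)OCC(N)=O`, is not yet measured. It differs from compound 2 in one place: amino in place of (4-chlorobenzyl)oxy on a carbonyl carbon.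

Among the measured compounds shown here, only one measured step exists, and it bears on this change only loosely: the step from compound 1 to compound 2 brought in the ring-bearing group that compound 3 now gives up again, but what was replaced there was a phosphorus-bearing group, not an amino group, so the direction of the new step cannot be read from it directly. The earlier step shows that changes in this part of the structure can move the half-life strongly in this assay. Compound 3 is therefore expected to land below compound 2, by a step of roughly a 3.8-fold lower number from compound 2 to compound 3 (0.58 log units; beyond the scatter), with wide uncertainty. The estimate for compound 3 is 3 h, within a range from 0.6 h to 15 h.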

Compound 3, half-life: 0.383 h
Beside the measured number, compound 3's estimate is 7.8-fold (0.89 log units) above it, and the stated range ends above it.
By their numbers in this assay, from the lowest: compound 1; then compound 3; then compound 2.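

In this assay, amino in place of (4-chlorobenzyl)oxy on a carbonyl carbon gives a 30-fold lower number from compound 2 to compound 3 (1.47 log units; beyond the scatter) as a large step, so the long half-life of compound 2 is not kept once this group is exchanged for amino. Replacing the phosphorus-bearing group with the carbamoylmethyl group gives a 2.6-fold higher number from compound 1 to compound 3 (0.41 log units; beyond the scatter) as only a modest step, which places the amide much nearer the phosphorus-bearing compound than the chlorobenzyl ester on this scale. Among these three compounds, the ester end carrying the (4-chlorobenzyl)oxy group stands well apart from the other two, but nothing measured here tells what lies behind these differences.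

This single exchange changes several things at once, so the compounds shown leave open whether the half-life follows the ring, the chlorine or the ester oxygen. A plain benzyl ester would test the chlorine, a methyl ester the ring, and a benzylamino group on the same carbonyl carbon would test the oxygen against nitrogen while keeping a ring.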